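Notes on the amide aryl change, compound 3 to compound 4

A few compounds are considered here, and "the series" means these few. Any claim that something is new, unique, unknown or untested is made for them only; others in the source may bear on it.

Values in a functional assay on the whole organism for inhibition, with Mus musculus as the target, at a dose of 1 mg/kg by the oral route; on this read-out higher numbers stand for more inhibition at the one dose given (going by the name of the read-out) and lower numbers for less inhibition:
Compound 1 `CCCN(C(=O)c1c(O)c2c(Cl)cccc2n(C)c1=O)c1ccccc1` gives 94%.
Compound 2 `C=CCN(C(=O)c1c(O)c2c(Cl)cccc2n(C)c1=O)c1ccccc1` gives 59%.
Compound 3 `COc1cccc2c1c(O)c(C(=O)N(C)c1ccc(F)cc1F)c(=O)n2C` gives 88%.

Compound 3 stands second highest of the three numbers; its gap to compound 1 is within the scatter, while compound 2 lies beyond the scatter below it. Compound 4 `COc1ccc(N(C)C(=O)c2c(O)c3c(OC)cccc3n(C)c2=O)cc1` differs from compound 3 in one place: 4-methoxyphenyl in place of 2,4-difluorophenyl on an amide-type nitrogen. Among the compounds with values here, the only measured step, a number 35 percentage points lower from compound 1 to compound 2 (beyond the scatter), concerns the saturated chain carbon on the amide-type nitrogen, not the aryl group, so no measured step bears on this change directly. It does show that a single change at this nitrogen can move the number a great deal, as compound 1 against compound 2 demonstrates. Without a closer guide, compound 4 is expected to stay near compound 3, with an expected step of a number 8 percentage points lower from compound 3 to compound 4 (within the scatter). The estimate for compound 4 is 80%, between 55% and 96%.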

Compound 4, a percentage reported as inhibition, in the whole organism at one dose (the size of the read-out at that dose, not a potency): 84%
For compound 4 the middle estimate is 4 percentage points below the measured one, within the range that was stated.
By their numbers in this assay, from the lowest: compound 2; then compounds 4, 3 and 1 (each within the scatter of the next).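

In this assay the aryl group on the amide-type nitrogen is now read directly: 4-methoxyphenyl in place of 2,4-difluorophenyl gives a number 4 percentage points lower from compound 3 to compound 4 (within the scatter). At this position, then, a swap that removes both fluorines and adds a hydrogen-bond acceptor leaves the number within the scatter at the one dose given. No measured evidence accounts for this result. Still open, on these data alone, is how this position would respond to an amine or a carboxylic acid on the aryl group, and whether a benzyl group could replace the aryl group there.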